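The compounds below may be only part of what the source reports. "The series", "measured", "known", "first", "only" and "open" are said of these compounds alone.

Measured so far:
compound 1 `Cn1nc(-c2ccnc(Nc3ccc(O)cc3)n2)c2ccccc21` — 8430 nM
compound 2 `CCn1nc(-c2ccnc(Nc3cccc([N+](=O)[O-])c3)n2)c2ccccc21` — 2820 nM

In a functional assay on HCT-116 cells (Homo sapiens) for antiproliferative activity, read by MTT assay, with a stated time of 72 h (a lower number here means a stronger inhibitor of growth, a higher number a weaker inhibitor of growth), compound 2 gives 2820 nM, the lowest of the two numbers; compound 1 gives 8430 nM, a gap beyond the scatter. Compound 3 `CCn1nc(-c2ccnc(Nc3ccc(O)cc3)n2)c2ccccc21` is not yet measured. It differs from compound 2 in 4-hydroxyphenyl in place of 3-nitrophenyl on a nitrogen on an aromatic ring. Within the data shown here, no measured pair shows this change on its own. Compound 1 also carries 4-hydroxyphenyl, and because compound 1 gives 8430 nM in this assay, compound 3 is expected to move to a higher number, a step of about a 2.5-fold higher number from compound 2 to compound 3 (0.39 log units; beyond the scatter). Compound 3 is estimated at 7000 nM, in a range from 3000 nM to 16000 nM.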

Compound 3, concentration for 50% growth inhibition: 5290 nM
Estimate against measurement, compound 3: 1.3-fold (0.12 log units) above, and the stated range covers the measured number.
By their numbers in this assay, from the lowest: compounds 2, 3 and 1 (each within the scatter of the next, the first and the last beyond it).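

In this assay, 4-hydroxyphenyl in place of 3-nitrophenyl on a nitrogen on an aromatic ring can now be read alone, as a 1.9-fold higher number from compound 2 to compound 3 (0.27 log units; within the scatter). Methyl in place of hydrogen on a saturated chain carbon bound to an aromatic nitrogen reads as a 1.6-fold lower number from compound 1 to compound 3 (0.20 log units; within the scatter), so neither single change gives a step beyond the scatter. No measurement bearing on the cause of either step is available. As far as these compounds go, whether an amine or a carboxylic acid in place of the hydroxyl, or a longer chain in place of ethyl, gives a step beyond the scatter stays open.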